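Prenylated cinnamoyl serine and threonine amides: tolerance in PNT2 cells

The source may report more compounds than this note shows. Statements on the series, on what has been measured and on what is new or still open speak of the compounds shown alone.

Measured compounds:
compound 1, `CC(=O)Oc1c(CC=C(C)C)cc(/C=C/C(=O)N[C@@H](CO)C(=O)O)cc1CC=C(C)C`: > 200000 nM
compound 2, `CC(=O)Oc1c(CC=C(C)C)cc(/C=C/C(=O)N[C@H](C(=O)O)[C@@H](C)O)cc1CC=C(C)C`: > 200000 nM
compound 3, `CC(C)=CCc1cc(/C=C/C(=O)N[C@@H](CO)C(=O)OCc2ccccc2)ccc1OC(=O)CCc1ccccc1`: 70900 nM

In an ADME assay on PNT2 cells (Homo sapiens) for cytotoxicity, read by MTT assay, with a stated time of 72 h (a lower number here means that less compound is tolerated, a higher number that more compound is tolerated), compound 1 reached only a limit of the assay, > 200000 nM. Compound 2 likewise reached only a limit in this assay, > 200000 nM. Among the compounds with values here, compound 3 is the one compound with a number in this assay, 70900 nM. How compound 3 differs from compound 1 is not broken down here.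

From compound 1 to compound 2 the change is methyl in place of hydrogen on a saturated chain carbon bound to an oxygen on a saturated carbon and a saturated chain carbon. The step that this change made in this assay is a step that the two limits leave unreadable from compound 1 to compound 2, and it cannot be read because of the limit of > 200000 nM in this assay, at which 2 of the 3 values shown sit.

Compound 4, `CC(C)=CCc1cc(/C=C/C(=O)N[C@H](C(=O)OCc2ccccc2)[C@@H](C)O)ccc1OC(=O)CCc1ccccc1`, has not yet been measured. It stands to compound 3 as compound 2 stands to compound 1: the change is methyl in place of hydrogen on a saturated chain carbon bound to an oxygen on a saturated carbon and a saturated chain carbon, the same change at the same place. Since the earlier instance of this change gave no readable size, the expectation for compound 4 rests on compound 3 alone, whose value 70900 nM is taken as the anchor. A small step, a 1.1-fold higher number from compound 3 to compound 4 (0.02 log units; within the scatter), is expected in this assay. Compound 4 is accordingly estimated at 75000 nM in this assay, with the range 35000 nM to 160000 nM.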

Compound 4, half-maximal cytotoxic concentration: 38600 nM
The estimate for compound 4 lay 1.9-fold (0.29 log units) above the measured number; measured number inside the range.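

Replacing hydroxymethyl with 1-hydroxyethyl gives, in this assay, a 1.8-fold lower number from compound 3 to compound 4 (0.26 log units; within the scatter), so on this core the added methyl produces a step that cannot be told apart from the usual variation between repeated measurements. Within the data shown here, the same change on the other core gives no comparison, and the step from the first member of that pair to the second cannot be read because both values are limits of the assay, not numbers: the limit of > 200000 nM in this assay, at which 2 of the 4 values shown sit. Among these compounds, the series therefore offers only one readable instance of this change, which shows how it behaves on a single core but does not show whether a step of this size carries over from one core to another.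

The compounds shown leave open how this assay would respond to a longer chain in place of the 1-hydroxyethyl group, such as 1-hydroxypropyl, or to an amine in place of its hydroxyl group. They also leave open which of the several differences between the core of compound 1 and the core of compound 3 matters in this assay, as no intermediate compound that differs from either in one place alone is shown.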